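The compounds below may be only part of what the source reports. "The series", "measured", "known", "first", "only" and "open" are said of these compounds alone.

Measured so far:

- Compound 1 `N#Cc1ccc(NC(=S)OCCc2ccccn2)cc1` gives 45000 nM in an ADME assay on MT4 cells (Homo sapiens) for cytotoxicity, read by MTT assay; a lower number here means that less compound is tolerated, a higher number that more compound is tolerated.
- Compound 2 `CC(=O)c1ccc(NC(=S)OCCc2ccccn2)cc1` reaches only the assay limit of >= 100000 nM in this assay.
- Compound 3 `Fc1ccc(NC(=S)OCCc2ccccn2)cc1` reaches only the assay limit of > 100000 nM in this assay.

Compound 3 therefore stands at the limit of > 100000 nM in this assay, at which 1 of the 3 values shown sits, and no number is known for it. Compound 2 sits at the limit of >= 100000 nM in this assay, at which 1 of the 3 values shown sits, so the step that the two limits leave unreadable from compound 2 to compound 3 cannot be read. For the measured compounds named here, the one readable comparison at this position is an at least 2.2-fold higher number from compound 1 to compound 3 (0.34 log units; beyond the scatter), with an at least 2.2-fold higher number from compound 1 to compound 2 (0.34 log units; beyond the scatter) pointing the same way: exchanging the group on the aromatic carbon moves the read-out from a measured number to the limit in both cases.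

Compound 4 `O=[N+]([O-])c1ccc(NC(=S)OCCc2ccccn2)cc1` carries nitro in place of fluoro on an aromatic carbon. Nitro has not been measured at this position, and with compound 3 at the limit the step from fluoro to nitro has no numbered starting point. The expectation for compound 4 is therefore a step of an at least 1.2-fold lower number from compound 3 to compound 4 (0.09 log units; that floor lies within the scatter) in this assay, with a fair chance that only a limit is reported again. The estimate for compound 4 is 80000 nM, with a range from 25000 nM to 250000 nM.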

Compound 4, half-maximal cytotoxic concentration: > 100000 nM
Compound 4: a limit, no number; the forecaster's own chance of this, stated with the estimate: 55%; middle value at least 1.2-fold (0.09 log units) away from the limit.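

In this assay compound 4 stands at a limit, not at a number, and it is the same limit as for compound 3: the limit of > 100000 nM in this assay, at which 2 of the 4 values shown sit.

Nitro in place of cyano gives an at least 2.2-fold higher number from compound 1 to compound 4 (0.34 log units; beyond the scatter), so a third group on this aromatic carbon, para to a large group, moves the read-out from a measured number to a limit, and compound 1 remains the only compound of the four with a number in this assay. The steps from compound 2 to compound 4 and from compound 3 to compound 4 cannot be read, so no order among acetyl, fluoro and nitro follows from these data.

Still open, as far as these compounds go, is how far compound 2, compound 3 and compound 4 lie from one another beyond the limits. Also open, from the compounds shown here alone, is whether an amine or a carboxylic acid on the same aromatic carbon gives a measured number, as cyano does, or a limit.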